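A sulfonamide in place of the pentylphenyl arm

The source may hold more compounds than are shown below. What is called first, only, known or untested is meant among the compounds shown, and "the series" means these compounds.

Going by the values given here, compound 2 `CCCCCc1ccc(-c2cn(C[C@H](O)[C@H]3OC(=O)C(OCc4ccccc4)=C3OCc3ccccc3)nn2)cc1` is the only compound of the three measured that returns a number in a functional assay on SW-620 cells (Homo sapiens) for antiproliferative activity, read by MTT assay, with a stated time of 72 h; on this read-out higher numbers stand for weaker inhibition and lower numbers for stronger inhibition: compound 2 gives 12200 nM. Compound 1 `Cc1ccc(-c2cn(C/C=C3\OC(=O)C(OCc4ccccc4)=C3OCc3ccccc3)nn2)cc1` reaches only a limit of the assay in this assay, where compound 1 gives > 100000 nM. Compound 3 `COc1ccc(-c2cn(C/C=C3\OC(=O)C(OCc4ccccc4)=C3OCc3ccccc3)nn2)cc1` likewise stops at a limit, and in this assay compound 3 gives > 100000 nM. Among the compounds with values here, the one measured step, a step that the two limits leave unreadable from compound 1 to compound 3, cannot be read, as both ends sit at the limit, and the limit of > 100000 nM in this assay, at which 2 of the 3 values shown sit, sums up that two of the three values stand there.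

Compound 4 `O=C1O[C@H]([C@@H](O)Cn2cc(CNS(=O)(=O)c3ccc(Cl)cc3)nn2)C(OCc2ccccc2)=C1OCc1ccccc1` differs from compound 2 by (((4-chlorophenyl)sulfonyl)amino)methyl in place of 4-pentylphenyl on an aromatic carbon. No measured step touches this part of the core, so nothing among the shown steps bears on it in size or direction. With two of three values at the limit, the expectation for compound 4 in this assay is weaker inhibition, a step of a 3.3-fold higher number from compound 2 to compound 4 (0.52 log units; beyond the scatter) beyond the scatter, and compound 4 is estimated at 40000 nM, in the range 8000 nM to 150000 nM.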

Compound 4, half-maximal inhibitory concentration: 18000 nM
The estimate for compound 4 lay 2.2-fold (0.35 log units) above the measured number; low and high end bracket the measured number.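

Exchanging 4-pentylphenyl for (((4-chlorophenyl)sulfonyl)amino)methyl on the aromatic carbon of the five-membered aromatic ring with 3 nitrogen gives, in this assay, a 1.5-fold higher number from compound 2 to compound 4 (0.17 log units; within the scatter), so the read-out does not separate the two compounds. The entering group brings a hydrogen-bond donor, hydrogen-bond acceptors, sulfur and chlorine that the leaving group lacks, so for this pair the 4-pentylphenyl arm is not required for a measurable number. Compound 4 also stays clear of the limit of the assay: the limit of > 100000 nM in this assay, at which 2 of the 4 values shown sit.

The compounds shown leave open whether the sulfonyl group or the chlorine matters here, as each enters together with the rest of the arm. As far as these compounds go, how a primary amine or a carboxylic acid on this carbon would read also remains open.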